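The source may report more compounds than this note shows. Statements on the series, on what has been measured and on what is new or still open speak of the compounds shown alone.

Of the compounds shown here, three built on a shared core have been measured in a functional assay on H4 cells with growth hormone secretagogue receptor type 1 (Homo sapiens) as the target, read by FLIPR; a higher number here means that more compound is needed for the effect, a lower number that less compound is needed. Compound 1 `CC(C)(N)C(=O)N[C@H](COCc1ccccc1)c1nnnn1CCOC(=O)NCCCO` gives 5.5 nM. Compound 2 `CN(CCCCO)C(=O)OCCn1nnnc1[C@@H](COCc1ccccc1)NC(=O)C(C)(C)N` gives 3.8 nM, the lowest of the three numbers; compound 1 sits nearest, with a 1.4-fold lower number from compound 1 to compound 2 (0.16 log units; within the scatter), while compound 3 sits furthest away. Compound 3 `CC(=O)NCCCCNC(=O)OCCn1nnnc1[C@@H](COCc1ccccc1)NC(=O)C(C)(C)N` gives 82.5 nM, and the large move a 15-fold higher number from compound 1 to compound 3 (1.18 log units; beyond the scatter) accompanies an acetamide entering where a hydroxy group stood.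

Compound 4 `CC(=O)N[C@@H]1CCN(C(=O)OCCn2nnnc2[C@@H](COCc2ccccc2)NC(=O)C(C)(C)N)C1` has not yet been measured. It differs from compound 2 in one place: 3-acetamidopyrrolidin-1-yl in place of (4-hydroxybutyl)(methyl)amino on a carbonyl carbon. As in compound 3, an acetamido group enters and the hydroxy group leaves, though here the acetamido sits on a five-membered non-aromatic ring. Going by the values given here, the one step that bears directly on this change is expected to repeat in direction, so a higher number is anticipated for compound 4, roughly an 11-fold higher number from compound 2 to compound 4 (1.02 log units; beyond the scatter), because of a 22-fold higher number from compound 2 to compound 3 (1.34 log units; beyond the scatter). The ring may temper the loss, so the estimate for compound 4 in this assay is 40 nM, expected to fall between 10 nM and 160 nM.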

Compound 4, half-maximal effective concentration: 3.3 nM
Beside the measured number, compound 4's estimate is 12-fold (1.08 log units) above it; the measured number lies below the stated range.
By their numbers in this assay, from the lowest: compounds 4, 2 and 1 (each within the scatter of the next); then compound 3.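

In this assay, an acetamido group on this carbonyl carbon does not by itself go with a high number: the 3-acetamidopyrrolidin-1-yl group of compound 4 stands level with the (4-hydroxybutyl)(methyl)amino group (a 1.2-fold lower number from compound 2 to compound 4 (0.06 log units; within the scatter)) and with the (3-hydroxypropyl)amino group (a 1.7-fold lower number from compound 1 to compound 4 (0.22 log units; within the scatter)). The large gap instead separates two groups that both carry an acetamido group (a 25-fold lower number from compound 3 to compound 4 (1.40 log units; beyond the scatter)), so the open (4-acetamidobutyl)amino chain and the five-membered ring cannot be treated as equivalent at this position. Nothing available accounts for this gap.

It remains open whether the defined stereocentre of the ring matters, since its mirror-image arrangement is not among the compounds shown. On these data alone, it is also open whether an amine or a carboxylic acid in place of the acetamido group on the ring would keep the number this low.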